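Cyanoethylpyrrolidine in place of piperidine on the saturated ring

The source may report more compounds than this note shows. Statements on the series, on what has been measured and on what is new or still open speak of the compounds shown alone.

Measured compounds:
compound 2 `Cc1nn([C@H](C)c2ccc(Cl)cc2Cl)c2nc(N3CC[C@H](N4CCCCC4)[C@H](C)C3)cnc12` gives 361 nM
compound 1 `Cc1nn([C@H](C)c2ccc(Cl)cc2Cl)c2nc(N3CC[C@H](N4CCC[C@H]4CCS(C)(=O)=O)[C@H](C)C3)cnc12` gives "not determined" (no result reported)

For the measured compounds named here, in an assay on CCRF-CEM cells for antagonist activity at C-C chemokine receptor type 4 (Homo sapiens), read by CellTiter-Glo, with stated times of 30 min and 60 min, in the presence of a further agent that is not named here (a higher number here means a weaker inhibitor, a lower number a stronger inhibitor), compound 2 gives 361 nM; it is the only number in hand, as compound 1 carries no result. Compound 3 `Cc1nn([C@H](C)c2ccc(Cl)cc2Cl)c2nc(N3CC[C@H](N4CCC[C@H]4CCC#N)[C@H](C)C3)cnc12` differs from compound 2 by 2-(2-cyanoethyl)pyrrolidin-1-yl in place of piperidin-1-yl on a saturated ring carbon. Going by the values given here, no measured step covers this change, so the direction rests on no comparison. A step from compound 2 to compound 3 of a 1.8-fold lower number from compound 2 to compound 3 (0.26 log units; within the scatter) is expected, at the edge of the scatter. Compound 3 is estimated at 200 nM, within 60 nM to 700 nM.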

Compound 3, half-maximal inhibitory concentration: 865 nM
The estimate for compound 3 lay 4.3-fold (0.64 log units) below the measured number, and the stated range ends below it.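

In this assay, for the compounds shown here, 2-(2-cyanoethyl)pyrrolidin-1-yl in place of piperidin-1-yl on the saturated ring carbon gives a 2.4-fold higher number from compound 2 to compound 3 (0.38 log units; beyond the scatter) as the first measured step at this position. The position tolerates this larger group with only a modest loss, and compound 3 keeps a measurable value. Nothing in hand accounts for the step. From the compounds shown here alone, whether the five-membered ring or the cyanoethyl chain carries the loss stays open, as the two change together. Also open, going by these compounds, is how an unsubstituted pyrrolidine or a morpholine would read at this position.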